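The source may hold more compounds than are shown below. What is called first, only, known or untested is meant among the compounds shown, and "the series" means these compounds.

Measured so far:
compound 1 `COc1ccccc1-n1nncc1CN1C(=O)C2(C(C#N)=C(N)Oc3c2c2nc4ccccc4nc2c2ccccc32)c2ccccc21` — > 50000 nM
compound 2 `Cc1ccccc1-n1nncc1CN1C(=O)C2(C(C#N)=C(N)Oc3c(N)cc4nc5ccccc5nc4c32)c2ccccc21` — > 50000 nM

In an ADME assay on HUVEC cells (Homo sapiens) for antiproliferative activity, read by MTT assay, with a stated time of 48 h (on this read-out higher numbers stand for weaker inhibition and lower numbers for stronger inhibition), compound 1 gives > 50000 nM, which is a limit of the assay and not a number. In this assay compound 2 gives > 50000 nM, likewise a limit and not a number. Compound 2 therefore stands at the limit of > 50000 nM in this assay, at which 2 of the 2 values shown sit. Within the data shown here, no step between measured compounds can be drawn from two limits, so no measured step size is available.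

Compound 3 `Cc1ccc(C)c(-n2nncc2CN2C(=O)C3(C(C#N)=C(N)Oc4c(N)cc5nc6ccccc6nc5c43)c3ccccc32)c1` differs from compound 2 by methyl in place of hydrogen on an aromatic carbon. Among the measured compounds shown here, with both measured values sitting at the limit and no measured step to rest on, the step from compound 2 to compound 3 expected in this assay is a step that the limit leaves unreadable from compound 2 to compound 3, that is none beyond the scatter. Compound 3 is estimated at 80000 nM, with a range from 30000 nM to 300000 nM, and most likely this assay will again report only a limit for compound 3.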

Compound 3, half-maximal inhibitory concentration: > 50000 nM
Compound 3: a limit, no number; the forecaster's own chance of this, stated with the estimate: 85%; the middle value is on the limit's open side.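

No step can be read from compound 2 to compound 3, because both give a limit and not a number: the limit of > 50000 nM in this assay, at which 3 of the 3 values shown sit.

The compounds shown leave open whether any compound of this series gives a measurable value in this assay and what methyl in place of hydrogen changes there.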